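The source may report more compounds than this note shows. Statements on the series, on what has been measured and on what is new or still open speak of the compounds shown alone.

Measured compounds:
compound 1 `COc1cc2c(Oc3c(F)cc(NC(=O)NN4C(=O)CSC4c4c(F)cccc4F)cc3F)ccnc2cc1OCCCN1CCCC1` — 230 nM
compound 2 `CCN1CCN(CCCOc2cc3nccc(Oc4c(F)cc(NC(=O)NN5C(=O)CSC5c5c(F)cccc5F)cc4F)c3cc2OC)CC1` — 73 nM

In a functional assay on HT-29 cells (Homo sapiens) for antiproliferative activity, read by MTT assay, with a stated time of 72 h (a lower number here means a stronger inhibitor, a higher number a weaker inhibitor), compound 2 holds the lower of the two numbers shown, and its only neighbour is compound 1. For the measured compounds named here, the single measured step, a 3.2-fold lower number from compound 1 to compound 2 (0.50 log units; beyond the scatter), is the sole guide to how this position responds to a change of group.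

Compound 3 `COc1cc2c(Oc3c(F)cc(NC(=O)NN4C(=O)CSC4c4c(F)cccc4F)cc3F)ccnc2cc1OCCCN1CCc2sccc2C1` is not yet measured. It differs from compound 2 in one place: a group of 9 heavy atoms (7 carbon, 1 nitrogen, 1 sulfur; one five-membered aromatic ring with 1 hetero atom, one six-membered non-aromatic ring with 1 hetero atom) in place of a group of 8 heavy atoms (6 carbon, 2 nitrogen; one six-membered non-aromatic ring with 2 hetero atoms), on a saturated chain carbon, three bonds along the chain from an oxygen on an aromatic ring. This is the same position that was altered in the measured step, so that step, modest in size, gives a feel for how much the number can move when the group on this chain is exchanged. Going by the values given here, no measured pair, however, swaps the group that leaves here for a fused bicyclic group of the kind that enters, so the direction of the step cannot be read from the data.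

Compound 3 is therefore expected to give 120 nM, with a likely range from 40 nM to 400 nM. That estimate corresponds to an expected 1.6-fold higher number from compound 2 to compound 3 (0.22 log units; within the scatter), a step not clearly beyond the scatter.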

Compound 3, half-maximal inhibitory concentration: 1410 nM
Estimate against measurement, compound 3: 12-fold (1.07 log units) below, and the stated range ends below it.
By their numbers in this assay, from the lowest: compound 2; then compound 1; then compound 3.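

In this assay, for the compounds shown here, this position on the chain turns out to be far more sensitive than the one earlier step suggested. Putting the two-ring group, with its five-membered aromatic ring, in place of 4-ethylpiperazin-1-yl gives a large loss (a 19-fold higher number from compound 2 to compound 3 (1.29 log units; beyond the scatter)), well beyond the earlier gain from pyrrolidin-1-yl to 4-ethylpiperazin-1-yl (a 3.2-fold lower number from compound 1 to compound 2 (0.50 log units; beyond the scatter)). The same entering group also falls behind pyrrolidin-1-yl (a 6.1-fold higher number from compound 1 to compound 3 (0.79 log units; beyond the scatter)), so it gives the highest number of the three whichever group it replaces, and no measurement at hand accounts for this drop.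

The compounds shown carry only three groups at this place, so they cannot separate the contribution of the second ring from that of the sulfur atom or of the missing second ring nitrogen. A plain piperidine, a morpholine or a 4-methylpiperazine on the same chain would help to show which of these features goes with the rise in the number, and a longer chain would show whether the pattern among these three groups holds at a different distance from the oxygen.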